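A few compounds are considered here, and "the series" means these few. Any claim that something is new, unique, unknown or untested is made for them only; others in the source may bear on it.

Compound 1 `CC(C)C(c1ncco1)c1ccc(-c2ccc3cccc(F)c3c2)[nH]c1=O`: 64 nM
Compound 2 `CCn1ncc2c(F)cc(-c3ccc(C(CC)(CC)c4nnc(C)[nH]4)c(=O)[nH]3)cc21`: 90 nM

In a functional assay on CHO cells for antagonist activity at prostaglandin E2 receptor EP3 subtype (Homo sapiens), read by cAMP accumulation (a lower number here means a stronger inhibitor, a higher number a weaker inhibitor), compound 1 gives 64 nM, and compound 2 gives 90 nM. These two numbers lie within the scatter of each other, so neither compound stands apart. Compound 3 `CC(C)C(c1ncc[nH]1)c1ccc(-c2ccc3cccc(F)c3c2)[nH]c1=O` has not yet been measured in this assay. It differs from compound 1 in one place: 1H-imidazol-2-yl in place of 1,3-oxazol-2-yl on a saturated chain carbon bound to an aromatic carbon and a saturated chain carbon. Among the compounds with values here, no pair of measured compounds differs in only this way, so no measured step guides the expectation. The expected step is a 1.1-fold lower number from compound 1 to compound 3 (0.03 log units; within the scatter), which is none beyond the scatter. Compound 3 is estimated at 60 nM, with a range from 20 nM to 200 nM.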

Compound 3, half-maximal inhibitory concentration: 33 nM
Estimate against measurement, compound 3: 1.8-fold (0.26 log units) above; the range from low to high includes it.
By their numbers in this assay, from the lowest: compounds 3, 1 and 2 (each within the scatter of the next, the first and the last beyond it).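

In this assay, 1H-imidazol-2-yl in place of 1,3-oxazol-2-yl on a saturated chain carbon bound to an aromatic carbon and a saturated chain carbon gives a 1.9-fold lower number from compound 1 to compound 3 (0.29 log units; within the scatter). This position therefore accepts a ring with a hydrogen-bond donor as well as one without, with no change beyond the scatter. No evidence is available that bears on this result. Left open is how 1-methyl-1H-imidazol-2-yl, which carries a methyl group on the ring nitrogen in place of that hydrogen, would read out at this position. Going by these compounds, a six-membered pyridin-2-yl ring there is equally open.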